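Heteroaryl swap on the outer amide and dog clearance

The source may hold more compounds than are shown below. What is called first, only, known or untested is meant among the compounds shown, and "the series" means these compounds.

Three compounds share one core and differ only in the aryl group on the outer carbonyl carbon. In an in vivo ADME assay on the whole organism (strain Mongrel) for pharmacokinetics, with Canis familiaris (Canis lupus familiaris) as the target (on this read-out lower numbers stand for slow clearance and higher numbers for fast clearance), compound 1 `C[C@@H](NC(=O)C1(NC(=O)c2ccc(Br)nc2)CC1)c1ccc(-n2nc(Cl)c3ccccc32)cc1F` gives 2.6 mL/min/kg. In this assay compound 2 `C[C@@H](NC(=O)C1(NC(=O)c2cncc(Cl)n2)CC1)c1ccc(-n2nc(Cl)c3ccccc32)cc1F` gives 10.5 mL/min/kg. In this assay compound 3 `C[C@@H](NC(=O)C1(NC(=O)c2cncc(Br)c2)CC1)c1ccc(-n2nc(Cl)c3ccccc32)cc1F` gives 3.8 mL/min/kg, which places compound 3 second highest of the three, close to compound 1 and well apart from compound 2. The measured steps show a 4.0-fold higher number from compound 1 to compound 2 (0.61 log units; beyond the scatter), a 1.5-fold higher number from compound 1 to compound 3 (0.16 log units; within the scatter) and a 2.8-fold lower number from compound 2 to compound 3 (0.44 log units; beyond the scatter).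

Compound 4 `Cc1nnsc1C(=O)NC1(C(=O)N[C@H](C)c2ccc(-n3nc(Cl)c4ccccc43)cc2F)CC1` arises from compound 3 by the change (4-methyl-1,2,3-thiadiazol-5-yl in place of 5-bromopyridin-3-yl on a carbonyl carbon). Within the data shown here, no measured step involves this thiadiazole, so the record for this position is the only guide: exchanging one six-membered heteroaryl for another moved the read-out by at most a modest amount, and two of three steps stayed small. On that basis the step of a 1.3-fold higher number from compound 3 to compound 4 (0.12 log units; within the scatter) is expected to be small, with the direction uncertain. Compound 4 is therefore estimated at 5 mL/min/kg in this assay, within a range of 2 mL/min/kg to 14 mL/min/kg.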

Compound 4, clearance: 9.6 mL/min/kg
Compound 4: middle estimate off by 1.9-fold (0.28 log units), on the low side; the range from low to high includes it.
By their numbers in this assay, from the lowest: compounds 1 and 3 (each within the scatter of the next); then compounds 4 and 2 (each within the scatter of the next).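

In this assay, among these compounds, 4-methyl-1,2,3-thiadiazol-5-yl is the first five-membered ring on this carbonyl carbon, and it does not stay with the two bromopyridines: the record shows a 2.5-fold higher number from compound 3 to compound 4 (0.40 log units; beyond the scatter) and a 3.7-fold higher number from compound 1 to compound 4 (0.57 log units; beyond the scatter), whereas it matches 6-chloropyrazin-2-yl, with a 1.1-fold lower number from compound 2 to compound 4 (0.04 log units; within the scatter). Ring size therefore does not sort these groups, since compound 2 carries a six-membered ring and still sits with compound 4, so two quite different heteroaryl groups share the higher numbers while only the two bromopyridines give the lower numbers. No supporting measurement is available to explain this split.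

Bromine and the pyridine ring occur only together here, so the compounds shown leave open which of them goes with the lower numbers. A plain pyridin-3-yl, a 5-chloropyridin-3-yl or a thiadiazole bearing bromine instead of methyl would separate the two.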